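Changing the Aryl Group on a Shared Core

The source may hold more compounds than are shown below. What is called first, only, known or untested is meant among the compounds shown, and "the series" means these compounds.

Compound 1 `COc1cc(/C=C/C(=O)C2=C(/C=C/c3ccc(O)c(OC)c3)NC(=O)NC2c2ccccc2)ccc1O`: 50000 nM
Compound 2 `COc1cc(/C=C/C(=O)C2=C(/C=C/c3ccc(O)c(OC)c3)NC(=O)NC2c2ccc(C)cc2)ccc1O`: 100000 nM
Compound 3 `COc1cc(/C=C/C(=O)C2=C(/C=C/c3ccc(O)c(OC)c3)NC(=O)NC2c2ccc(N(C)C)cc2)ccc1O`: 12500 nM

These three compounds share one core and differ only in the aromatic ring attached to a saturated ring carbon. They were tested in a functional assay on QG-56 cells (Homo sapiens) for cytotoxicity, read by MTT assay, with a stated time of 48 h; a lower number here means a stronger inhibitor, a higher number a weaker inhibitor. Compound 3 holds the lowest number of the three: a 4.0-fold lower number from compound 1 to compound 3 (0.60 log units; beyond the scatter), and an 8.0-fold lower number from compound 2 to compound 3 (0.90 log units; beyond the scatter). Compound 1 and compound 2 cannot be told apart, since a 2.0-fold higher number from compound 1 to compound 2 (0.30 log units; within the scatter).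

Compound 4 `COc1cc(/C=C/C(=O)C2=C(/C=C/c3ccc(O)c(OC)c3)NC(=O)NC2c2ccccc2Cl)ccc1O` has not yet been measured in this assay. Its change from compound 3 is this: 2-chlorophenyl in place of 4-(dimethylamino)phenyl on a saturated ring carbon. Within the data shown here, the steps that bear on it are the two that brought the dimethylamino group in, a 4.0-fold lower number from compound 1 to compound 3 (0.60 log units; beyond the scatter) and an 8.0-fold lower number from compound 2 to compound 3 (0.90 log units; beyond the scatter), both modest. Among the measured compounds shown here, nothing measured here shows what a chlorine on that ring does; the only guide is that the unsubstituted ring of compound 1 and the methyl ring of compound 2 gave similar, higher numbers. The gain seen at compound 3 is not expected to carry over, so for compound 4 the estimated step is a 4.0-fold higher number from compound 3 to compound 4 (0.60 log units; beyond the scatter). The estimate for compound 4 in this assay is 50000 nM, with a range from 15000 nM to 150000 nM.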

Compound 4, half-maximal inhibitory concentration: 100000 nM
Compound 4: the middle estimate sits 2.0-fold (0.30 log units) below what was measured, within the range that was stated.
By their numbers in this assay, from the lowest: compound 3; then compounds 1, 2 and 4 (each within the scatter of the next).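

In this assay, the 2-chlorophenyl group gives no separation from the unsubstituted phenyl ring, a 2.0-fold higher number from compound 1 to compound 4 (0.30 log units; within the scatter), or from the 4-methylphenyl ring, no change at the digits printed from compound 2 to compound 4 (within the scatter), so three different aryl groups at this saturated ring carbon now fall within the scatter of one another. Replacing 4-(dimethylamino)phenyl with 2-chlorophenyl gives an 8.0-fold higher number from compound 3 to compound 4 (0.90 log units; beyond the scatter), which leaves compound 3 as the only one of the four set apart from all the others, although this single swap changes both the substituent and its place on the aromatic ring. No supporting measurement explains why the dimethylamino compound differs from the rest.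

The compounds shown leave open whether the lower number of compound 3 belongs to dimethylamino specifically or would also appear with a smaller nitrogen group, such as a primary amine, or with an oxygen group, such as methoxy, on the same ring. They also leave open what chlorine would do on the ring in the position held by methyl in compound 2, as a 4-chlorophenyl group.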